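Bromo for Nitro on a Weakly Active Benzyl Thioether

This account rests on a few compounds, and the source may have more. Where it says the series, first, only, none or still open, it means among the compounds named here.

Measured so far:
compound 1, `O=[N+]([O-])c1ccccc1CSc1nnc(-c2ccc3c(c2)OCCO3)n1-c1ccccc1`: 69800 nM
compound 2, `O=[N+]([O-])c1cccc(CSc2nnc(-c3ccc4c(c3)OCCO4)n2-c2ccccc2)c1`: 45200 nM

Both compounds were tested in a functional assay on HeLa cells (Homo sapiens) for antiproliferative activity, read by MTT assay, with a stated time of 24 h; a higher number here means a weaker inhibitor, a lower number a stronger inhibitor. Within the data shown here, compound 1 gives 69800 nM, the highest of the two numbers, and the only neighbour is compound 2 with 45200 nM; the step of a 1.5-fold lower number from compound 1 to compound 2 (0.19 log units; within the scatter) stays within the scatter, so the two cannot be ranked.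

Compound 3, `Brc1ccccc1CSc1nnc(-c2ccc3c(c2)OCCO3)n1-c1ccccc1`, has not been measured. It differs from compound 1 by bromo in place of nitro on an aromatic carbon. Among the measured compounds shown here, no measured step shows this exchange: the single step on record only moved the nitro group to another carbon of the same ring and did not reach beyond the scatter. With nothing to point either way, the step of a 1.2-fold lower number from compound 1 to compound 3 (0.07 log units; within the scatter) is expected to stay within the scatter. Compound 3 is therefore estimated at 60000 nM, with a range from 20000 nM to 180000 nM.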

Compound 3, half-maximal inhibitory concentration: > 100000 nM
Compound 3 ended at the assay's limit; the forecaster's own chance of this, stated with the estimate: 15%; middle value at least 1.6-fold (0.22 log units) away from the limit.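

Compound 3 stands at a limit of this assay, not at a number: the limit of > 100000 nM in this assay, at which 1 of the 3 values shown sits.

Among these compounds, this is the first exchange of the nitro group itself rather than a shift around the ring, yet the floor of that step (an at least 1.4-fold higher number from compound 1 to compound 3 (0.15 log units; that floor lies within the scatter)) cannot separate 2-bromophenyl from 2-nitrophenyl. Among the compounds shown here, the other step (an at least 2.2-fold higher number from compound 2 to compound 3 (0.34 log units; beyond the scatter)) is the first on record to pass the scatter, so 2-bromophenyl on this chain reads as weaker than 3-nitrophenyl, and the true size of the gap may be larger than this floor.

On these data alone, what an amine or a carboxylic acid on this aromatic carbon would give remains open. So does whether either group would bring the number clearly below those of compound 1 and compound 2.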